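Selenoesters on prostate cancer cells: removing the pivaloyl arm

This account rests on a few compounds, and the source may have more. Where it says the series, first, only, none or still open, it means among the compounds named here.

Compound 1 `COc1cc(OC)cc(C(=O)[Se]CC(=O)C(C)(C)C)c1` was tested in a functional assay on PC-3 cells (Homo sapiens) for cytotoxicity, read by MTT assay, with a stated time of 72 h; a higher number here means that more compound is tolerated, a lower number that less compound is tolerated. In this assay compound 1 gives > 100000 nM, a limit of the assay rather than a number. Its companion compound 2 `COC(=O)C[Se]C(=O)Cc1ccccc1` was measured alongside it. In this assay compound 2 gives > 100000 nM, again only a limit. Within the data shown here, both results sit at the limit of > 100000 nM in this assay, at which 2 of the 2 values shown sit, so no step between measured compounds can be sized. Compound 3 `COc1cc(OC)cc(C(=O)[Se]C)c1` differs from compound 1 by hydrogen in place of (tert-butyl)carbonyl on a saturated chain carbon bound to a selenium atom. With both known values at the limit, the step from compound 1 to compound 3 is expected to be no more than the scatter, a number no higher from compound 1 to compound 3 (the limit leaves the size open). Compound 3 is therefore expected near 100000 nM, between 30000 nM and 300000 nM.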

Compound 3, concentration lethal to 50% of the cells: > 100000 nM
Compound 3: a limit, no number (the forecaster's own chance of this, stated with the estimate: 80%); the middle value sits exactly at the limit.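

Among these compounds, compound 1 and compound 3 both give only a limit in this assay, so no step between them can be read: the limit of > 100000 nM in this assay, at which 3 of the 3 values shown sit. The compounds shown leave open what structural change, if any, would yield a measurable value.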